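The source may report more compounds than this note shows. Statements on the series, on what has been measured and on what is new or still open speak of the compounds shown alone.

Compound 1 `COc1cc(N(Cc2nc3ccccc3[nH]2)S(=O)(=O)c2ccc(Br)cc2)cc(OC)c1OC`: 6890 nM
Compound 2 `COc1cc(N(Cc2nc3ccccc3[nH]2)S(=O)(=O)c2ccc(C(C)(C)C)cc2)cc(OC)c1OC`: 29800 nM
Compound 3 `COc1ccc(S(=O)(=O)N(Cc2nc3ccccc3[nH]2)c2cc(OC)c(OC)c(OC)c2)cc1OC`: 30400 nM

All three were measured in a functional assay on PC-3 cells (Homo sapiens) for inhibition, read by MTT assay, with a stated time of 48 h; on this read-out lower numbers stand for stronger inhibition and higher numbers for weaker inhibition. Compound 1 stands lowest of the three numbers; the step of a 4.3-fold higher number from compound 1 to compound 2 (0.64 log units; beyond the scatter) and the step of a 4.4-fold higher number from compound 1 to compound 3 (0.64 log units; beyond the scatter) both move away from it, while the step of a 1.0-fold higher number from compound 2 to compound 3 (0.01 log units; within the scatter) is within the scatter.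

Compound 4 `COc1cc(N(Cc2nc3ccccc3[nH]2)C(=O)c2ccc(F)cc2)cc(OC)c1OC` differs from compound 1 by (4-fluorophenyl)carbonyl in place of (4-bromophenyl)sulfonyl on a nitrogen on an aromatic ring. The two measured steps from compound 1 each changed only the aryl part on the sulfonyl sulfur and each weakened inhibition modestly. Within the data shown here, no measured step replaces the sulfonyl with a carbonyl, so the change to compound 4 goes beyond what the data cover. Compound 4 is therefore expected to show a modestly higher number, the step of a 2.2-fold higher number from compound 1 to compound 4 (0.34 log units; beyond the scatter), with wide uncertainty. The estimate for compound 4 in this assay is 15000 nM, within a range of 4000 nM to 60000 nM.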

Compound 4, half-maximal inhibitory concentration: 21900 nM
Estimate against measurement, compound 4: 1.5-fold (0.16 log units) below; the range from low to high includes it.
By their numbers in this assay, from the lowest: compound 1; then compounds 4, 2 and 3 (each within the scatter of the next).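

Until now, only the aryl part on the sulfonyl sulfur had changed. Compound 4 also replaces the sulfonyl link on this nitrogen with a carbonyl, and in this assay this gives a 3.2-fold higher number from compound 1 to compound 4 (0.50 log units; beyond the scatter), so the (4-fluorophenyl)carbonyl version sits on the weaker side of compound 1. No evidence on the cause of this step is available.

The change swaps the link and the halogen together, so their shares stay unseparated; (4-bromophenyl)carbonyl would isolate the link. As far as these compounds go, whether an amine or a carboxylic acid on that aromatic ring would lower the number also remains open.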